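Fluoronitrophenyl exchange on a diaminopyrimidine glutamate series

A few compounds are considered here, and "the series" means these few. Any claim that something is new, unique, unknown or untested is made for them only; others in the source may bear on it.

Of the compounds shown here, three have been measured in a functional assay on CCRF-CEM cells (Homo sapiens) for cytotoxicity, in the absence of a further agent; a higher number here means a weaker inhibitor, a lower number a stronger inhibitor. Compound 1 `Nc1nc(N)c(CCCN(Cc2ccc(NC(CCC(=O)O)C(=O)O)cc2)c2ccc([N+](=O)[O-])c(F)c2F)c(O)n1` gives only a limit in this assay, > 100000 nM. Compound 2 `Nc1nc(N)c(CCCN(Cc2ccc(NC(CCC(=O)O)C(=O)O)cc2)c2cc(F)ccc2[N+](=O)[O-])c(O)n1` likewise gives only a limit, > 100000 nM. Compound 3 `CC(C)(C)OC(=O)CCC(Nc1ccc(CN(CCCc2c(N)nc(N)nc2O)c2cc(F)ccc2[N+](=O)[O-])cc1)C(=O)OC(C)(C)C` gives 3400 nM in this assay. The change from compound 2 to compound 1, (2,3-difluoro-4-nitrophenyl in place of 5-fluoro-2-nitrophenyl on an amine nitrogen), yields a step that the two limits leave unreadable from compound 2 to compound 1; both values sit at the limit of > 100000 nM in this assay, at which 2 of the 3 values shown sit. Compound 4 `CC(C)(C)OC(=O)CCC(Nc1ccc(CN(CCCc2c(N)nc(N)nc2O)c2ccc([N+](=O)[O-])c(F)c2F)cc1)C(=O)OC(C)(C)C` carries the same change on the core of compound 3, (2,3-difluoro-4-nitrophenyl in place of 5-fluoro-2-nitrophenyl on an amine nitrogen); the difference between the two cores is not broken down here. Because a step that the two limits leave unreadable from compound 2 to compound 1 cannot be read, the value of compound 3, 3400 nM, is the main anchor for the expectation. For compound 4 the expected step is a 1.5-fold higher number from compound 3 to compound 4 (0.17 log units; within the scatter), wide in either direction. Compound 4 is thus estimated at 5000 nM, between 1200 nM and 30000 nM.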

Compound 4, half-maximal inhibitory concentration: 36000 nM
Compound 4: the middle estimate sits 7.2-fold (0.86 log units) below what was measured; the measured number lies above the stated range.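

In this assay, putting 2,3-difluoro-4-nitrophenyl in place of 5-fluoro-2-nitrophenyl on the amine nitrogen gives an 11-fold higher number from compound 3 to compound 4 (1.02 log units; beyond the scatter), a large loss on this one core. The same exchange cannot be read on the other core, where compound 1 and compound 2 each give only a limit and not a number: the limit of > 100000 nM in this assay, at which 2 of the 4 values shown sit. The series therefore shows the size of this change on a single core, and it does not show whether that size carries over from one core to another.

The compounds shown leave open what a plain 4-nitrophenyl on the same amine nitrogen would give. They also leave open whether a methyl ester in place of the tert-butyl esters would keep the step at this size.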